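Two Piperazine Ureas and an Ester-Bearing Analogue

A few compounds are considered here, and "the series" means these few. Any claim that something is new, unique, unknown or untested is made for them only; others in the source may bear on it.

Measured compounds:
- Compound 1, `CCCCCN(C)C(=O)N1CCN(C(=O)N(c2ccccc2)c2ccccc2)[C@H](C(=O)O)C1`: 15 nM
- Compound 2, `CCCCCN(CCCCC)C(=O)N1CCN(C(=O)N(c2ccccc2)c2cccc(Cl)c2)[C@H](C(=O)O)C1`: 0.4 nM

Both compounds share a core carrying a carboxylic acid and two urea groups, and both were tested in an assay for inhibition of Type-2 angiotensin II receptor (Rattus norvegicus); on this read-out lower numbers stand for stronger inhibition and higher numbers for weaker inhibition. Compound 1 gives 15 nM. Compound 2, which carries two pentyl chains on one urea nitrogen and a chlorine on one of the two phenyl rings of the other, gives 0.4 nM. Of the two numbers, compound 2 has the lower one, and the gap to compound 1 lies beyond the usual scatter of this assay; the two compounds differ in more than one place, so the two values alone are what they show.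

Compound 3, `CCCCCN(CCCCC)C(=O)N1CCN(C(=O)N(c2ccccc2)c2ccc(C(=O)OCC)cc2)[C@H](C(=O)O)C1`, has not yet been measured. It keeps the two pentyl chains of compound 2 and differs in one place: 4-(ethoxycarbonyl)phenyl in place of 3-chlorophenyl on an amide-type nitrogen. No pair among the measured compounds shows this exchange, so its size cannot be read from the data shown. The exchange replaces a small ring substituent with a larger one carrying two hydrogen-bond acceptors, and for compound 3 a modest move toward a higher number than compound 2 is expected, about a 3.8-fold higher number from compound 2 to compound 3 (0.57 log units; beyond the scatter). Compound 3 is therefore estimated at 1.5 nM, within a range of 0.3 nM to 8 nM.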

Compound 3, half-maximal inhibitory concentration: 35 nM
Beside the measured number, compound 3's estimate is 23-fold (1.37 log units) below it, outside the stated range (above it).
By their numbers in this assay, from the lowest: compound 2; then compound 1; then compound 3.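

Among the compounds shown, this is the only comparison that changes one place alone: in this assay, 4-(ethoxycarbonyl)phenyl in place of 3-chlorophenyl on the amide-type nitrogen gives an 88-fold higher number from compound 2 to compound 3 (1.94 log units; beyond the scatter) and so a clear loss of inhibition. The gap between compound 1 and compound 2 could not be assigned to any one part, since those two differ in more than one place, whereas here the two pentyl chains and the rest of the molecule stay the same and the change in number belongs to this ring substituent alone. This shows that inhibition is sensitive to the group on this nitrogen, but nothing available explains why this exchange has so large an effect.

Going by these compounds, the exchange alters both the substituent and the ring position given in its name, so it remains open which of these matters; 4-chlorophenyl or 3-(ethoxycarbonyl)phenyl on this nitrogen would separate the two. Also open, on these data alone, is how a carboxylic acid or an amine in place of the ethoxycarbonyl group would read in this assay.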